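The source may hold more compounds than are shown below. What is called first, only, known or untested is meant among the compounds shown, and "the series" means these compounds.

Working notes on the series. Two compounds carry numbers in an assay on liver for inhibition of sterol O-acyltransferase 1 (Rattus norvegicus), using microsomes; on this read-out lower numbers stand for stronger inhibition and higher numbers for weaker inhibition. Compound 1 `CCCCCCCCCCCCN(CCCCCCCCCCCC)S(=O)(=O)NC(=O)Nc1c(C(C)C)cccc1C(C)C` gives 69000 nM in this assay. Compound 2 `CC(C)c1cccc(C(C)C)c1OS(=O)(=O)NC(=O)OC1[C@H](C(C)C)CCC[C@H]1C(C)C` gives 5700 nM in this assay, the lowest of the two numbers shown, and its gap to compound 1 lies beyond the scatter. The step under examination leads from compound 2 to compound 3 `CC(C)c1cccc(C(C)C)c1OS(=O)(=O)NC(=O)OC1[C@@H](C(C)C)CCC[C@H]1C(C)C`, where (the two compounds have the same atoms and bonds; at least one stereo element is drawn with a configuration in one of them and without one in the other: 1 of 3 stereo elements differ; a stereocentre at a saturated ring carbon is drawn S in compound 2 and R in compound 3). Among the compounds with values here, no pair differing in one place has been measured, so nothing in the set shows how a change of this kind moves the number. A single stereocentre flipped at a saturated ring carbon could move the number either way; with no guidance from the shown compounds, the expected step of a 1.4-fold higher number from compound 2 to compound 3 (0.15 log units; within the scatter) is taken as small and uncertain, leaning slightly toward a weaker reading. Compound 3 is therefore estimated at 8000 nM, within a range of 2000 nM to 30000 nM.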

Compound 3, half-maximal inhibitory concentration: 3600 nM
For compound 3 the middle estimate is 2.2-fold (0.35 log units) above the measured one; the measured number falls inside the stated range.
By their numbers in this assay, from the lowest: compounds 3 and 2 (each within the scatter of the next); then compound 1.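

In this assay, within the data shown here, turning the stereocentre at this saturated ring carbon from S to R gives a 1.6-fold lower number from compound 2 to compound 3 (0.20 log units; within the scatter), the first reading of a change in one place. For this pair, this assay does not separate the two configurations, so the S or R drawing at this carbon shows no effect that stands clear of the scatter. One caveat applies to how firmly this pair speaks for the configuration: the fact that one of compounds 2 and 3 is drawn with a defined configuration and the other without, at the place where they differ

The compounds shown leave open whether the same insensitivity would hold at the other stereocentres of the ring. They also leave open whether a different group on this ring carbon, such as a methyl, a tert-butyl or a phenyl in place of the isopropyl, would make the configuration matter.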